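Trifluoromethyl in Place of Methyl on the Shared Core

The compounds below may be only part of what the source reports. "The series", "measured", "known", "first", "only" and "open" are said of these compounds alone.

Compound 1 `CN(C(=O)NC(=O)c1ccc(Cl)cc1Cl)c1nc(C(F)(F)F)c(C(=O)N/N=C/c2ccc(C(F)(F)F)cc2)s1`: in a functional assay on A549 cells (Homo sapiens) for inhibition, read by MTT assay, with a stated time of 72 h (a higher number here means a weaker inhibitor, a lower number a stronger inhibitor), compound 1 gives 9.4 ug/mL.
Compound 2 `CNc1nc(C)c(C(=O)N/N=C/c2cccc(C(F)(F)F)c2)s1`: compound 2 gives only a limit, > 100 ug/mL.
Compound 3 `CNc1nc(C)c(C(=O)N/N=C/c2cc(C(F)(F)F)cc(C(F)(F)F)c2)s1`: compound 3 gives only a limit, > 100 ug/mL.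

Compound 3 thus stands at the limit of > 100 ug/mL in this assay, at which 2 of the 3 values shown sit, where compound 2 also sits, so its value is a limit and not a number. Compound 4 `CNc1nc(C(F)(F)F)c(C(=O)N/N=C/c2cc(C(F)(F)F)cc(C(F)(F)F)c2)s1` differs from it by trifluoromethyl in place of methyl on an aromatic carbon. Among the measured compounds shown here, no measured step follows this change; the only measured step, a step that the two limits leave unreadable from compound 2 to compound 3, concerns a different place and its size cannot be read. For the measured compounds named here, compound 1 carries trifluoromethyl on the shared core but also a different group in place of the methylamino group, so it shows only that such a compound can give a number rather than a limit. The step of an at least 1.4-fold lower number from compound 3 to compound 4 (0.15 log units; that floor lies within the scatter) is therefore an uncertain expectation. Compound 4 is expected at 70 ug/mL, between 15 ug/mL and 200 ug/mL.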

Compound 4, half-maximal inhibitory concentration: > 100 ug/mL
Compound 4: no number, only a limit; the forecaster's own chance of this, stated with the estimate: 50%; middle value at least 1.4-fold (0.15 log units) from the limit.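

Compound 3 and compound 4 both give only a limit in this assay, and the step between them cannot be read. The compounds shown leave open whether trifluoromethyl in place of methyl alters inhibition at all.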